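Notes on a substituent series, cytotoxicity toward CCRF-CEM cells

The compounds below may be only part of what the source reports. "The series", "measured", "known", "first", "only" and "open" are said of these compounds alone.

Measured so far:
Compound 1, `CCc1cccc2c1nc(-c1c(F)cccc1F)n2Cc1c(F)cccc1F`, in a toxicity assay on CCRF-CEM cells (Homo sapiens) for cytotoxicity; a higher number here means that more compound is tolerated, a lower number that less compound is tolerated: 26.1 uM.
Compound 2, `CC(=O)N(C)c1cccc2c1nc(-c1c(F)cccc1F)n2Cc1c(F)cccc1F`, in this assay: > 100 uM, which is a limit of the assay and not a number.

Compound 2 therefore stands at the upper edge of what this assay reports, and its true position is known only as the limit of > 100 uM in this assay, at which 1 of the 2 values shown sits. Among the measured compounds shown here, the one measured step that bears on the next change is an at least 3.8-fold higher number from compound 1 to compound 2 (0.58 log units; beyond the scatter), a move from a plain hydrocarbon chain to a group carrying a carbonyl and a nitrogen, with the number rising beyond the scatter.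

Compound 3, `CC(C)=CCc1cccc2c1nc(-c1c(F)cccc1F)n2Cc1c(F)cccc1F`, is the next compound to be measured. Compared with compound 2 it shows (3-methylbut-2-en-1-yl in place of acetyl(methyl)amino on an aromatic carbon). This change runs the other way from the measured step: the acetyl(methyl)amino group leaves and a hydrocarbon chain returns, now with five carbon atoms instead of two. The expectation is a step of an at least 5.0-fold lower number from compound 2 to compound 3 (0.69 log units; beyond the scatter), downward, back toward the region of compound 1, on the ground that an at least 3.8-fold higher number from compound 1 to compound 2 (0.58 log units; beyond the scatter) went upward when the hydrocarbon chain was removed. Compound 2 sits at the limit. The size of the return step is therefore uncertain. For compound 3 the estimate in this assay is 20 uM, within a range from 6 uM to 70 uM.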

Compound 3, half-maximal toxic concentration: 28.3 uM
The estimate for compound 3 lay 1.4-fold (0.15 log units) below the measured number; the measured number falls inside the stated range.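

Replacing acetyl(methyl)amino with 3-methylbut-2-en-1-yl on this aromatic carbon gives an at least 3.5-fold lower number from compound 2 to compound 3 (0.54 log units; beyond the scatter), so the earlier rise does not depend on one particular pair of groups, and both hydrocarbon chains shown lie on the lower side of the amide-bearing compound, with none of the three compounds going against this. Ethyl and 3-methylbut-2-en-1-yl at the same position are separated by a 1.1-fold higher number from compound 1 to compound 3 (0.04 log units; within the scatter), which means that the larger chain with its double bond cannot be told apart from ethyl in this assay. The value of compound 2 is a limit of the assay and not a number, so the full size of both steps that touch it stays unknown: the limit of > 100 uM in this assay, at which 1 of the 3 values shown sits.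

The compounds shown do not separate the nitrogen of acetyl(methyl)amino from its carbonyl, so it remains open which part of the group goes with the higher number. A plain amine, a carboxylic acid or a longer saturated chain on this carbon would show whether the higher number extends beyond this one amide group and whether hydrocarbon chains in general stay in the range of compound 1 and compound 3.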